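Swapping a Benzofuran for an Ethoxyphenyl Group

This account rests on a few compounds, and the source may have more. Where it says the series, first, only, none or still open, it means among the compounds named here.

Measured so far in an assay on isolated protein for agonist activity at Bile acid receptor (Homo sapiens), read by AlphaScreen, with a stated time of 30 min; on this read-out lower numbers stand for smaller maximal responses and higher numbers for larger maximal responses:
compound 1 `COc1ccc(C2SC(C)C(=O)Nc3c2c(C)nn3-c2ccccc2C)c(OC)c1` gives 63%;
compound 2 `Cc1ccccc1-n1nc(C)c2c1NC(=O)[C@H](C)S[C@@H]2c1ccc(-c2cc3ccccc3o2)cc1` gives 17%;
compound 3 `Cc1nn(-c2ccccc2Cl)c2c1C(c1ccc(Oc3ccccc3)cc1)SC(C)C(=O)N2` gives 57%.

Compound 2 stands lowest of the three: its nearest neighbour is compound 3, a number beyond the scatter above it, and compound 1 lies further above still. Compound 4 `CCOc1cccc(-c2ccc([C@H]3S[C@@H](C)C(=O)Nc4c3c(C)nn4-c3ccccc3C)cc2)c1` differs from compound 2 in one place: 3-ethoxyphenyl in place of 1-benzofuran-2-yl on an aromatic carbon. Going by the values given here, no directly comparable step between measured compounds exists, so the expectation rests on compound 1 with 63% and compound 3 with 57%, both carrying an oxygen-bearing aromatic group on the shared core and both sitting well above compound 2. Compound 4 is therefore expected to rise, with a number 28 percentage points higher from compound 2 to compound 4 (beyond the scatter) as a moderate upward step beyond the scatter. The estimate for compound 4 is 45%, with a range from 20% to 70%.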

Compound 4, largest response reached (reported as efficacy), in percent of the reference or control that the assay uses: 13%
Beside the measured number, compound 4's estimate is 32 percentage points above it; measured number below the stated range.
By their numbers in this assay, from the lowest: compounds 4 and 2 (each within the scatter of the next); then compounds 3 and 1 (each within the scatter of the next).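

In this assay, putting 3-ethoxyphenyl in place of 1-benzofuran-2-yl gives a number 4 percentage points lower from compound 2 to compound 4 (within the scatter) and so leaves the two compounds inseparable. At this place, para to a large group, a single aromatic ring carrying an ethoxy chain and a fused two-ring group with its oxygen in the five-membered ring give matching responses. No measurement shown explains this match. On these data alone, whether an amine or a carboxylic acid at this place would give a different response remains open. So does whether a simple phenyl would match these two groups.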